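This account rests on a few compounds, and the source may have more. Where it says the series, first, only, none or still open, it means among the compounds named here.

Compound 2 `COc1ccc(/C=N/N(C)C(=O)c2ccccc2)cc1OC` gives 68% in a functional assay on the whole organism (lung, strain A/J) for inhibition, with Mus musculus as the target, with stated times of 1 h and 18 h, at a dose of 100 umol/kg by the oral route (on this read-out lower numbers stand for less inhibition and higher numbers for more inhibition at the one dose given (going by the name of the read-out)), the smaller of the two numbers recorded, though the gap to compound 1 lies within the scatter. Among the measured compounds shown here, compound 1 `COc1cccc(C(=O)N(C)/N=C/c2ccc(OC)c(OC)c2)c1` gives 77% in this assay, and the single measured step, a number 9 percentage points lower from compound 1 to compound 2 (within the scatter), concerns a different group on the same ring. Compound 3 `COc1ccc(/C=N/N(C)C(=O)c2ccc(Cl)cc2)cc1OC` differs from compound 2 in one place: chloro in place of hydrogen on an aromatic carbon. For the measured compounds named here, no measured step bears on a chloro entering, and the only step known stayed within the scatter, so compound 3 is expected to show no step beyond the scatter, no change at the digits printed from compound 2 to compound 3 (within the scatter). Compound 3 is estimated at 68%, between 50% and 84%.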

Compound 3, a percentage reported as inhibition, in the whole organism at one dose (the size of the read-out at that dose, not a potency): 54%
Estimate against measurement, compound 3: 14 percentage points above; low and high end bracket the measured number.
By their numbers in this assay, from the lowest: compound 3; then compounds 2 and 1 (each within the scatter of the next).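

In this assay, among the compounds shown here, the ring on the carbonyl carbon responds to a substituent for the first time: chloro in place of hydrogen, para to a large group, brings a number 14 percentage points lower from compound 2 to compound 3 (beyond the scatter). Exchanging 3-methoxyphenyl for 4-chlorophenyl on the carbonyl carbon brings a number 23 percentage points lower from compound 1 to compound 3 (beyond the scatter), so both steps ending at compound 3 lie beyond the scatter. Nothing available accounts for this lower number.

The compounds shown leave open whether the lower number is particular to chloro or would also follow an amine or a carboxylic acid at this place. They also leave open whether chloro elsewhere on this ring would give the same result.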